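Fluoro for methoxy on the cinnamoyl sultam series

The compounds below may be only part of what the source reports. "The series", "measured", "known", "first", "only" and "open" are said of these compounds alone.

Measured compounds:
compound 1 `O=C(/C=C/c1c[nH]c2ccc(F)cc12)N1CCC=CS1(=O)=O`: 18800 nM
compound 2 `COc1ccccc1/C=C/C(=O)N1CCC=CS1(=O)=O`: 100 nM
compound 3 `O=C(/C=C/c1ccoc1)N1CCC=CS1(=O)=O`: 20300 nM

All three share the same unsaturated amide core and differ only in the aryl group on the double bond. In a functional assay on HeLa cells (Homo sapiens) for inhibition, read by sulforhodamine B assay, with a stated time of 48 h (a lower number here means a stronger inhibitor of growth, a higher number a weaker inhibitor of growth), compound 1 gives 18800 nM and compound 3 gives 20300 nM; both sit far apart from compound 2, which in this assay gives 100 nM, the lowest number of the three and beyond the scatter from each of the others. Compound 2 is thus the most potent of the measured set.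

Compound 4 `O=C(/C=C/c1ccccc1F)N1CCC=CS1(=O)=O` has not yet been measured. It is derived from compound 2 by fluoro in place of methoxy on an aromatic carbon. Among the measured compounds shown here, no step between measured compounds of this kind exists here, so the expected effect rests only on the fact that the remaining single-atom aryl variants, compound 1 and compound 3, are weak. The step from compound 2 to compound 4 is expected to go toward a higher number, beyond the scatter, estimated at a 20-fold higher number from compound 2 to compound 4 (1.30 log units; beyond the scatter). Compound 4 is estimated at 2000 nM, within a range from 300 nM to 15000 nM.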

Compound 4, concentration for 50% growth inhibition: 13700 nM
Compound 4: the middle estimate sits 6.9-fold (0.84 log units) below what was measured; the measured number falls inside the stated range.
By their numbers in this assay, from the lowest: compound 2; then compounds 4, 1 and 3 (each within the scatter of the next).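

In this assay, the first step read in this series is a large one: fluoro in place of methoxy on an aromatic carbon, ortho to a large group, gives a 140-fold higher number from compound 2 to compound 4 (2.14 log units; beyond the scatter). The six-membered aromatic ring and a group at this place are both kept in compound 4, so these two features alone do not bring the low number of compound 2; at this position, the methoxy cannot be exchanged for fluoro without a large loss. Nothing available explains the size of this step.

The compounds shown leave open whether the step reflects the loss of methoxy or the entry of fluoro, which a plain hydrogen, a hydroxy or a chloro at this place would help to separate. As far as these compounds go, whether a longer ether such as ethoxy or an amine would hold the low number also remains open.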